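Swapping dichloro for dimethoxy on a benzylamine aminoquinoxaline core

The compounds below may be only part of what the source reports. "The series", "measured", "known", "first", "only" and "open" are said of these compounds alone.

Among the compounds with values here, compound 1 `Nc1cc(N)c2nc(-c3ccccc3)c(NCc3ccc(Cl)c(Cl)c3)nc2c1` is the only one of three related compounds to give a number in a functional assay on SK-MEL-28 cells (Homo sapiens) for inhibition, read by sulforhodamine B assay, with a stated time of 48 h (on this read-out higher numbers stand for lower toxicity in this test and lower numbers for higher toxicity in this test), where compound 1 gives 93300 nM. Compound 2 `Nc1cc(N)c2nc(-c3ccccc3)c(Sc3ccc(F)cc3)nc2c1` gives in this assay only a limit, < 100000 nM. Compound 3 `Nc1cc(N)c2nc(-c3ccccc3)c(Sc3ccc(Cl)c(Cl)c3)nc2c1` likewise gives in this assay only a limit, < 100000 nM. Within the data shown here, the one single-point step, a step that the two limits leave unreadable from compound 2 to compound 3, therefore carries no readable size, and the sole solid footing is the limit of < 100000 nM in this assay, at which 2 of the 3 values shown sit.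

Compound 4 `COc1ccc(CNc2nc3cc(N)cc(N)c3nc2-c2ccccc2)cc1OC` differs from compound 1 by 3,4-dimethoxyphenyl in place of 3,4-dichlorophenyl on a saturated chain carbon bound to a nitrogen on an aromatic ring. Among the measured compounds shown here, no measured step touches this kind of exchange: the step between compound 2 and compound 3 concerns a different pair of groups on a sulfur and is unreadable anyway. With nothing to lean on, compound 1 is taken as the anchor and little movement beyond the scatter is expected in this assay, so the estimated step is a 1.1-fold lower number from compound 1 to compound 4 (0.04 log units; within the scatter). Compound 4 is thus expected to give about 85000 nM, with a plausible range from 30000 nM to 200000 nM.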

Compound 4, concentration lethal to 50% of the cells: 67600 nM
For compound 4 the middle estimate is 1.3-fold (0.10 log units) above the measured one; measured number inside the range.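

In this assay, within the data shown here, the exchange on a saturated chain carbon bound to a nitrogen on an aromatic ring gives the first step of readable size, a 1.4-fold lower number from compound 1 to compound 4 (0.14 log units; within the scatter). At this place, 3,4-dimethoxyphenyl and 3,4-dichlorophenyl therefore cannot be told apart in this test, even though the entering group brings hydrogen-bond acceptors and more heavy atoms. This one step is all there is to go on, as the only other step cannot be read and the remaining values are limits: the limit of < 100000 nM in this assay, at which 2 of the 4 values shown sit.

Still open, as far as these compounds go, is whether any group at this place moves the number beyond the scatter, for instance an amine or a carboxylic acid on the phenyl ring, or a longer chain in place of the single chain carbon. With one pair, nothing can yet be said about the 3,4-substituents in general.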